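Working notes on the amine side-chain series

The source may report more compounds than this note shows. Statements on the series, on what has been measured and on what is new or still open speak of the compounds shown alone.

Measured so far:
compound 1 `O=C(CCN1CCCCC1)c1cc2ccc(O)cc2oc1=O` gives > 200000 nM
compound 2 `Cc1cc(O)cc2oc(=O)c(C(=O)CCN(C)C)cc12` gives > 200000 nM

In an assay on cells for inhibition of Amine oxidase [flavin-containing] A (Homo sapiens), read by fluorescence, spectrophotometry and Amplex Red, with stated times of 60 min and 30 min (on this read-out lower numbers stand for stronger inhibition and higher numbers for weaker inhibition), compound 2 sits at a limit of the assay, not a number. The same holds for compound 1 in this assay. Both values rest at the limit of > 200000 nM in this assay, at which 2 of the 2 values shown sit.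

Compound 3 `Cc1cc(O)cc2oc(=O)c(C(=O)CCN3CCCCC3)cc12` differs from compound 2 by piperidin-1-yl in place of dimethylamino on a saturated chain carbon, two bonds along the chain from a carbonyl carbon. Among the compounds with values here, no step between measured compounds is available, so no size can be read off. The expectation is no change beyond the scatter: compound 3 is estimated at 300000 nM, between 100000 nM and 1000000 nM, a step that the limit leaves unreadable from compound 2 to compound 3, most likely again reported only as a limit.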

Compound 3, half-maximal inhibitory concentration: 136000 nM
For compound 3 the middle estimate is 2.2-fold (0.34 log units) above the measured one, and the stated range covers the measured number.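

In this assay, within the data shown here, compound 3 is the first of the series to return a number rather than a limit, so piperidin-1-yl in place of dimethylamino gives a first reading at this chain position: an at least 1.4-fold lower number from compound 2 to compound 3 (0.16 log units; that floor lies within the scatter). Methyl in place of hydrogen on an aromatic carbon gives an at least 1.4-fold lower number from compound 1 to compound 3 (0.16 log units; that floor lies within the scatter). Both steps are only floors, since compound 1 and compound 2 each stand at a limit: the limit of > 200000 nM in this assay, at which 2 of the 3 values shown sit.

From the compounds shown here alone, the true size of either step stays open. So does whether morpholin-4-yl in place of piperidin-1-yl, or a longer chain, would give a step beyond the scatter.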